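Swapping Fluoro for Trifluoromethyl on the Fused Ring

The source may hold more compounds than are shown below. What is called first, only, known or untested is meant among the compounds shown, and "the series" means these compounds.

Compound 1 `C1=NCC(CC2=Cc3ccccc3CC2)N1` and compound 2 `Fc1ccc2c(c1)C=C(CC1CN=CN1)CC2` share one core and differ only by a fluoro on an aromatic carbon. In a functional assay for binding affinity to Norepinephrine transporter (Rattus norvegicus), read by radioligand binding, in the presence of a further agent that is not named here (on this read-out lower numbers stand for stronger inhibition and higher numbers for weaker inhibition), compound 1 gives 50.1 nM, and compound 2 gives 50.1 nM; the step of no change at the digits printed from compound 1 to compound 2 (within the scatter) shows that the fluoro left affinity where it was, within the scatter. Compound 2 therefore stands level with compound 1 on these numbers. Compound 3 `FC(F)(F)c1ccc2c(c1)C=C(CC1CN=CN1)CC2` has not yet been measured; it differs from compound 2 by trifluoromethyl in place of fluoro on an aromatic carbon. Among the measured compounds shown here, the only measured step bearing on this kind of change, no change at the digits printed from compound 1 to compound 2 (within the scatter), was flat, which gives no ground to expect a large move when one substituent replaces another on the same aromatic carbon. Compound 3 is therefore expected to shift by a 1.2-fold higher number from compound 2 to compound 3 (0.08 log units; within the scatter), a step within the scatter. The estimate for compound 3 in this assay is 60 nM, with a range from 20 nM to 180 nM.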

Compound 3, inhibition constant: < 10000 nM
Compound 3 gave a limit, no number; the forecaster's own chance of this, stated with the estimate: 2%; the middle value does not contradict the limit.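

In this assay compound 3 gave only a limit of < 10000 nM and not a number, so its steps from compound 1 and compound 2 cannot be read. The compounds shown leave open whether trifluoromethyl in place of fluoro changes affinity, and by how much.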